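Chloro substitution on the indole core of the sulfonamide series

A few compounds are considered here, and "the series" means these few. Any claim that something is new, unique, unknown or untested is made for them only; others in the source may bear on it.

Measured compounds:
compound 1, `O=S(=O)(Nc1cccc2cc[nH]c12)c1ccc(Cl)cc1`, 6 ug/mL
compound 2, `O=S(=O)(Nc1cccc2c(Cl)c[nH]c12)c1ccc(Cl)cc1`, 8.8 ug/mL
compound 3, `O=[N+]([O-])c1ccc(S(=O)(=O)Nc2cccc3cc[nH]c23)cc1`, 15 ug/mL

All three were run in a functional assay on KB cells (Homo sapiens) for antiproliferative activity, read by colorimetric assay and MTT assay; on this read-out higher numbers stand for weaker inhibition and lower numbers for stronger inhibition. Compound 1 and compound 3 share a core but differ in one place, (nitro in place of chloro on an aromatic carbon), and that difference gave a 2.5-fold higher number from compound 1 to compound 3 (0.40 log units; beyond the scatter).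

Compound 4, `O=[N+]([O-])c1ccc(S(=O)(=O)Nc2cc(Cl)cc3cc[nH]c23)cc1`, is not yet measured. It arises from compound 3 by chloro in place of hydrogen on an aromatic carbon. The same kind of change was made once before, from compound 1 to compound 2, (chloro in place of hydrogen on an aromatic carbon), with the result a 1.5-fold higher number from compound 1 to compound 2 (0.17 log units; within the scatter). The place differs, though: in compound 2 the chloro sits on a five-membered aromatic ring with 1 nitrogen, two ring bonds from the ring nitrogen, whereas in compound 4 it sits on a six-membered aromatic ring of carbon only, meta to a fused ring, meta to a large group and para to a fused ring. Among the measured compounds shown here, a step of similar size is expected here, a 1.2-fold higher number from compound 3 to compound 4 (0.08 log units; within the scatter), because the only precedent, a 1.5-fold higher number from compound 1 to compound 2 (0.17 log units; within the scatter), stayed within the scatter. Compound 4 is therefore estimated at 18 ug/mL, with a likely range from 9 ug/mL to 36 ug/mL.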

Compound 4, half-maximal inhibitory concentration: 12 ug/mL
Estimate against measurement, compound 4: 1.5-fold (0.18 log units) above, and the stated range covers the measured number.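

In this assay chloro in place of hydrogen on an aromatic carbon gave a 1.3-fold lower number from compound 3 to compound 4 (0.10 log units; within the scatter) on the nitro-bearing core, and the two steps on the two cores cannot be told apart: the same change on two cores in this assay, a 1.5-fold higher number (0.17 log units; within the scatter) from compound 1 to compound 2 and a 1.3-fold lower number (0.10 log units; within the scatter) from compound 3 to compound 4, 1.8-fold (0.26 log units) apart, within the scatter of two such steps. On these two cores, then, the change carries over with no step beyond the scatter. This does not show that chloro is without effect in general, nor that its place is irrelevant, since the two chloro groups sit on different rings and two small steps give no direction.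

Open, as far as these compounds go, is whether chloro on the six-membered ring behaves the same on the core of compound 1. Also open, from the compounds shown here alone, is whether an amine or a methoxy group on that carbon would give a step beyond the scatter.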